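A few compounds are considered here, and "the series" means these few. Any claim that something is new, unique, unknown or untested is made for them only; others in the source may bear on it.

Measured compounds:
Compound 1, `CCCCN(c1nc2c(C(=O)O)cccc2o1)[C@H](C)c1ccc(-c2ccccc2-c2nnn[nH]2)cc1`: 238 nM
Compound 2, `Cc1ccc(-c2nc(=O)o[nH]2)c(-c2ccc([C@@H](C)N(CC3CC3)c3nc4c(C(=O)O)cccc4o3)cc2)c1`: 2920 nM

In an ADME assay on the whole organism (Macaca fascicularis) for pharmacokinetics, read by LC-MS, using cassette dosing, at a dose of 1 mg/kg by the oral route (a lower number here means less compound in the circulation, a higher number more compound in the circulation at the dose given), compound 1 gives 238 nM, the lowest of the two numbers; compound 2 gives 2920 nM, a gap that lies beyond the scatter of this assay. Compound 3, `CCCCN(c1nc2c(CO)cccc2o1)[C@H](C)c1ccc(-c2ccccc2-c2nnn[nH]2)cc1`, differs from compound 1 in one place: hydroxymethyl in place of carboxy on an aromatic carbon of the shared core. Going by the values given here, no pair of measured compounds shows this change on its own, so nothing measured here gives its size or direction, and the expectation rests on the change alone. The step expected from compound 1 to compound 3 in this assay is a 2.1-fold higher number from compound 1 to compound 3 (0.32 log units; beyond the scatter), a rise that may stay within the scatter. Compound 3 is therefore estimated at 500 nM, with a range from 120 nM to 2500 nM.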

Compound 3, maximal plasma concentration: 20.7 nM
Beside the measured number, compound 3's estimate is 24-fold (1.38 log units) above it; measured number outside the range, below it.
By their numbers in this assay, from the lowest: compound 3; then compound 1; then compound 2.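

In this assay, the group on this aromatic carbon of the shared core clearly matters: putting hydroxymethyl in place of carboxy gives an 11-fold lower number from compound 1 to compound 3 (1.06 log units; beyond the scatter), a large step. Going by these compounds alone, this is the first comparison here in which only one place changes, so the step can be tied to this swap alone, with the rest of compound 1 left intact. Of these two groups, carboxy goes with more compound in the circulation, but no measurement here explains the drop or shows which part of the compound's passage through the body it arises in.

As far as these compounds go, only these two groups can be compared at this position, so it remains open whether a primary amide or a methyl ester would stand nearer to carboxy or to hydroxymethyl. From the compounds shown here alone, it is also open whether the same swap would have a step of similar size on compound 2.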